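The source may report more compounds than this note shows. Statements on the series, on what has been measured and on what is new or still open speak of the compounds shown alone.

Measured so far:
compound 1, `O=C(Nc1ccccc1)c1ccc(/N=N\c2c[nH]c3ccccc23)cc1`, 147000 nM in a functional assay on MCF7 cells (Homo sapiens) for inhibition, read by MTT assay, with a stated time of 72 h; a lower number here means a stronger inhibitor, a higher number a weaker inhibitor;
compound 2, `O=C(Nc1ccccc1[N+](=O)[O-])c1ccc(/N=N\c2c[nH]c3ccccc23)cc1`, 101000 nM;
compound 3, `O=C(Nc1cccc(Cl)c1)c1ccc(/N=N\c2c[nH]c3ccccc23)cc1`, 82700 nM.

All three share one core and differ only in the group carried on the amide-type nitrogen. Compound 3 has the smallest number of the three, yet a 1.2-fold lower number from compound 2 to compound 3 (0.09 log units; within the scatter) and a 1.8-fold lower number from compound 1 to compound 3 (0.25 log units; within the scatter) both sit within the scatter, so the three compounds cannot be told apart on these data.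

Compound 4 is `O=C(Nc1ccccc1F)c1ccc(/N=N\c2c[nH]c3ccccc23)cc1`. Its difference from compound 3 is 2-fluorophenyl in place of 3-chlorophenyl on an amide-type nitrogen. The measured steps that bear on this change are all small: a 1.5-fold lower number from compound 1 to compound 2 (0.16 log units; within the scatter), a 1.8-fold lower number from compound 1 to compound 3 (0.25 log units; within the scatter) and a 1.2-fold lower number from compound 2 to compound 3 (0.09 log units; within the scatter). Each of these changed the group on the amide-type nitrogen, and none moved the number beyond the scatter. A swap of one halogen-bearing phenyl for another on the same nitrogen is therefore expected to leave the number about where compound 3 stands, with no shift beyond the scatter in either direction.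

Compound 4 is expected to give 100000 nM, between 45000 nM and 220000 nM, which is an estimated step of a 1.2-fold higher number from compound 3 to compound 4 (0.08 log units; within the scatter).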

Compound 4, half-maximal inhibitory concentration: 83800 nM
Compound 4: middle estimate off by 1.2-fold (0.08 log units), on the high side; low and high end bracket the measured number.
By their numbers in this assay, from the lowest: compounds 3, 4, 2 and 1 (each within the scatter of the next).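

In this assay, putting 2-fluorophenyl in place of 3-chlorophenyl on the amide-type nitrogen gives a 1.0-fold higher number from compound 3 to compound 4 (0.01 log units; within the scatter), so replacing both the halogen and its numbered place on the phenyl ring produces no readable difference. The other two new comparisons also stay within the scatter, at a 1.2-fold lower number from compound 2 to compound 4 (0.08 log units; within the scatter) and a 1.8-fold lower number from compound 1 to compound 4 (0.24 log units; within the scatter), which means that fluoro cannot be told apart from nitro or from hydrogen in this series, and the four compounds remain indistinguishable at this position. Nothing measured here accounts for the four groups reading alike, and no separate data bear on the result.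

So far, this nitrogen has carried only a phenyl ring, either bare or with one nitro, chloro or fluoro group, so it remains open whether an amine or a carboxylic acid on that ring, or a longer alkyl chain in place of the ring, would give a step beyond the scatter. As far as these compounds go, it is equally open whether a change elsewhere in the shared core would do so.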